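The source may hold more compounds than are shown below. What is called first, only, known or untested is meant among the compounds shown, and "the series" means these compounds.

Working notes on the series. Compound 1 `CCCc1nc(CC)c(C(=O)OCCCOCc2ccccc2)n1Cc1ccc(-c2ccccc2S(=O)(=O)NC(=O)OCCC(C)C)cc1F` stands lowest of the two numbers in an assay on isolated protein for binding affinity to Type-2 angiotensin II receptor (Homo sapiens) (a lower number here means a stronger inhibitor, a higher number a weaker inhibitor), where compound 1 gives 2 nM. Its nearest neighbour is compound 2 `CCCc1nc(CC)c(C(=O)NCCCOc2ccccc2)n1Cc1ccc(-c2ccccc2S(=O)(=O)NC(=O)OCCC(C)C)cc1F`, which in this assay gives 9 nM; the step of a 4.5-fold higher number from compound 1 to compound 2 (0.65 log units; beyond the scatter) is the only measured one.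

Compound 3 `CCCc1nc(CC)c(C(=O)OCCCN2C(=O)c3ccccc3C2=O)n1Cc1ccc(-c2ccccc2S(=O)(=O)NC(=O)OCCC(C)C)cc1F` differs from compound 1 by a group of 11 heavy atoms (8 carbon, 1 nitrogen, 2 oxygen; one five-membered non-aromatic ring with 1 hetero atom, one six-membered aromatic ring of carbon only) in place of a group of 8 heavy atoms (7 carbon, 1 oxygen; one six-membered aromatic ring of carbon only), on a saturated chain carbon, three bonds along the chain from an oxygen next to a carbonyl group. The measured step from compound 1 to compound 2 bears only loosely on this change, since it alters two things at once, the carbonyl-linked oxygen and the group carried on the chain, whereas compound 3 keeps the ester of compound 1 and changes only the group on the chain. Because a 4.5-fold higher number from compound 1 to compound 2 (0.65 log units; beyond the scatter) was modest, a modest weakening is expected here too, smaller than that step. Compound 3 is estimated at 5 nM, with a range of 1.5 nM to 20 nM; the expected step is a 2.5-fold higher number from compound 1 to compound 3 (0.40 log units; beyond the scatter).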

Compound 3, half-maximal inhibitory concentration: 3 nM
The estimate for compound 3 lay 1.7-fold (0.22 log units) above the measured number, within the range that was stated.
By their numbers in this assay, from the lowest: compounds 1 and 3 (each within the scatter of the next); then compound 2.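

In this assay, replacing benzyloxy with the group of 11 heavy atoms, with the ester kept, gives a 1.5-fold higher number from compound 1 to compound 3 (0.18 log units; within the scatter), so this saturated chain carbon accepts a second ring, a nitrogen and two double bonds outside aromatic rings without a change beyond the scatter. This single-place change is a cleaner reading of the chain end than a 4.5-fold higher number from compound 1 to compound 2 (0.65 log units; beyond the scatter), where the carbonyl-linked oxygen and the group on the chain differ together. No measurement shown explains why the number holds across this replacement.

Among the compounds shown here, how much of the earlier step belongs to the amide nitrogen alone stays open, as no pair here isolates it. Also open, going by these compounds, is what a primary amine or a carboxylic acid on the same chain carbon would give, or a longer chain carrying either ring group.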